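A few compounds are considered here, and "the series" means these few. Any claim that something is new, unique, unknown or untested is made for them only; others in the source may bear on it.

Measured compounds:
compound 1 `COc1ccccc1[C@@H](O)COC(=O)/C=C/c1ccccc1`, 51700 nM
compound 2 `COc1ccc([C@H](O)COC(=O)/C=C/c2ccccc2)cc1`, 33500 nM
compound 3 `COc1cccc([C@@H](O)COC(=O)/C=C/c2ccccc2)c1OC`, 82700 nM

All three were read in an ADME assay on Vero cells (Chlorocebus sabaeus) for cytotoxicity, read by MTT assay, with a stated time of 72 h; a higher number here means that more compound is tolerated, a lower number that less compound is tolerated. Compound 3 and compound 1 differ by one change, (hydrogen in place of methoxy on an aromatic carbon), and it gave a 1.6-fold lower number from compound 3 to compound 1 (0.20 log units; within the scatter). Compound 2 and compound 3 differ in their cores, and that difference is not broken down here; their values lie apart beyond the scatter. Compound 4 `O=C(/C=C/c1ccccc1)OC[C@@H](O)c1ccccc1` has not yet been measured. It differs from compound 2 by hydrogen in place of methoxy on an aromatic carbon, the same kind of change as that from compound 3 to compound 1, though the place is not the same: there the leaving group sat ortho to a methoxy group and meta to a large group, here it sits para to a large group. Resting on the step of a 1.6-fold lower number from compound 3 to compound 1 (0.20 log units; within the scatter), the step from compound 2 to compound 4 is expected to be a 1.1-fold lower number from compound 2 to compound 4 (0.05 log units; within the scatter). Compound 4 is estimated at 30000 nM in this assay.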

Compound 4, half-maximal cytotoxic concentration: 39200 nM
Compound 4: middle estimate off by 1.3-fold (0.12 log units), on the low side; measured number inside the range.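

In this assay, hydrogen in place of methoxy on an aromatic carbon gave a 1.2-fold higher number from compound 2 to compound 4 (0.07 log units; within the scatter), and the two cores can be compared directly: the same change on two cores in this assay, a 1.6-fold lower number (0.20 log units; within the scatter) from compound 3 to compound 1 and a 1.2-fold higher number (0.07 log units; within the scatter) from compound 2 to compound 4, 1.9-fold (0.27 log units) apart, within the scatter of two such steps. Carried from one core to the other, the change therefore gave steps that cannot be told apart. Going by these compounds alone, that does not establish a shared direction or size for the change: each step lies within the scatter, the evidence is only two pairs, and the methoxy sits at a different place in each.

The compounds shown leave open what an amine or a carboxylic acid would do on the aromatic ring. They also leave open how the change would behave on other cores.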